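Chloro for fluoro on the benzyl group of compound 2

This account rests on a few compounds, and the source may have more. Where it says the series, first, only, none or still open, it means among the compounds named here.

Of the compounds shown here, two with one shared core have been measured. In an assay on membranes from striatum (strain Sprague-Dawley) for displacement of a labelled ligand from sodium-dependent dopamine transporter (Rattus norvegicus), read by scintillation counting, with a stated time of 120 min (a lower number here means a stronger inhibitor, a higher number a weaker inhibitor), compound 1 `Fc1ccc(C(SCCNC2CCN(Cc3ccccc3)CC2)c2ccc(F)cc2)cc1` gives 32.9 nM. In this assay compound 2 `Fc1ccc(CN2CCC(NCCSC(c3ccc(F)cc3)c3ccc(F)cc3)CC2)cc1` gives 25.5 nM. The single change between them is fluoro in place of hydrogen on an aromatic carbon, and it gave a 1.3-fold lower number from compound 1 to compound 2 (0.11 log units; within the scatter), so compound 2 stands beside compound 1 on the numbers shown and cannot be told apart from it.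

Compound 3 `Fc1ccc(C(SCCNC2CCN(Cc3ccc(Cl)cc3)CC2)c2ccc(F)cc2)cc1` has not yet been measured. It differs from compound 2 by chloro in place of fluoro on an aromatic carbon, which read one bond further out is 4-fluorobenzyl to 4-chlorobenzyl, with the halogen para to a large group. Among the compounds with values here, no measured step swaps fluoro for chloro; the only step at hand, from compound 1 to compound 2, touched an aromatic carbon with a halogen and stayed within the scatter. The expected step from compound 2 to compound 3 is therefore a 1.1-fold lower number from compound 2 to compound 3 (0.03 log units; within the scatter), no more than the scatter. Compound 3 is estimated at 24 nM, within the range 9 nM to 65 nM.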

Compound 3, inhibition constant: 39.6 nM
Estimate against measurement, compound 3: 1.7-fold (0.22 log units) below; the range from low to high includes it.
By their numbers in this assay, from the lowest: compounds 2, 1 and 3 (each within the scatter of the next).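

In this assay, chloro in place of fluoro on the benzyl group gives a 1.6-fold higher number from compound 2 to compound 3 (0.19 log units; within the scatter), and chloro in place of hydrogen on that same aromatic carbon gives a 1.2-fold higher number from compound 1 to compound 3 (0.08 log units; within the scatter). The earlier pair compared only hydrogen and fluoro at this position, and a third substituent now joins them: with hydrogen, fluoro or chloro para to a large group, all three steps stay within the scatter, so the three compounds cannot be told apart and no order among these substituents can be drawn from them. Nothing available explains why this position shows so little response to these changes.

From the compounds shown here alone, all three substituents are small, and two of them are halogens, so it remains open whether a group of a different kind here, such as a methoxy group, a nitrile, an amine or a carboxylic acid, would move the number beyond the scatter. Going by these compounds, it also remains open whether chloro would give the same flat result elsewhere on the benzyl ring, or on the two 4-fluorophenyl rings of the shared core.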